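The compounds below may be only part of what the source reports. "The series", "measured", "known", "first", "only" and "open" are said of these compounds alone.

Measured so far in an ADME assay (liver) for metabolic stability, with Liver microsome (Homo sapiens) as the target, using microsomes; on this read-out lower numbers stand for slow clearance and higher numbers for fast clearance
Compound 1 `c1ccc(CNc2nnc(-c3ccc4cnccc4c3)o2)cc1` gives 120 mL.min-1.g-1
Compound 2 `Fc1cc2cc(-c3nnc(NCc4ccccc4)o3)ccc2cn1` gives 49 mL.min-1.g-1
Compound 3 `c1ccc(CNc2nnc(-c3c[nH]c4ncccc34)o2)cc1` gives 31 mL.min-1.g-1

Compound 3 sits within the scatter of compound 2 and clearly under compound 1 on these numbers. Compound 4 `Fc1cccc(CNc2nnc(-c3c[nH]c4ncccc34)o2)c1` is compound 3 with fluoro in place of hydrogen on an aromatic carbon so that phenyl becomes 3-fluorophenyl. Among the measured compounds shown here, the one measured exchange of this kind is a 2.4-fold lower number from compound 1 to compound 2 (0.39 log units; beyond the scatter) and it is modest, though beyond the scatter, but there the fluoro stands on the core and not on the phenyl. Only a small fall, perhaps none beyond the scatter, is therefore expected in this assay here. The expected step is a 1.1-fold lower number from compound 3 to compound 4 (0.06 log units; within the scatter) and it stays within the scatter. Compound 4 is estimated at 27 mL.min-1.g-1 with an expected range from 13 mL.min-1.g-1 to 55 mL.min-1.g-1 in this assay.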

Compound 4, intrinsic clearance in microsomes: 54 mL.min-1.g-1
For compound 4 the middle estimate is 2.0-fold (0.30 log units) below the measured one; measured number inside the range.
By their numbers in this assay, from the lowest: compounds 3, 2 and 4 (each within the scatter of the next); then compound 1.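

In this assay, fluoro on the phenyl of compound 3, meta to a large group, gives a 1.7-fold higher number from compound 3 to compound 4 (0.24 log units; within the scatter), so this position shows no clear change with this exchange. The lower number seen with fluoro on the core of compound 1 therefore does not carry over to the phenyl on this other core, and the same exchange reads differently in the two places: the same change on two cores in this assay, a 2.4-fold lower number (0.39 log units; beyond the scatter) from compound 1 to compound 2 and a 1.7-fold higher number (0.24 log units; within the scatter) from compound 3 to compound 4, 4.3-fold (0.63 log units) apart, beyond the scatter of two such steps

The compounds shown leave open whether a methoxy, a nitrile or an amine at this position would move the number beyond the scatter. They also leave open how fluoro on the core of compound 3 would read.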